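Extending the sulfonyl chain with an isopropylamino group

The source may hold more compounds than are shown below. What is called first, only, known or untested is meant among the compounds shown, and "the series" means these compounds.

Compound 1, `CC(C)(C)NC(=O)NCCS(=O)(=O)NC(=O)c1ccc(Nc2nc(NC3(c4ccc(Cl)cc4)CC3)nc(OCC(F)(F)F)n2)cc1`, gives 93% in an ADME assay on microsomes from liver (Rattus norvegicus) for metabolic stability, with a stated time of 10 min; on this read-out higher numbers stand for a more stable compound and lower numbers for a less stable compound.
Compound 2, `CC(C)C(=O)NCCS(=O)(=O)NC(=O)c1ccc(Nc2nc(NC3(c4ccc(Cl)cc4)CC3)nc(OCC(F)(F)F)n2)cc1`, gives 84% in this assay.
Compound 3, `CS(=O)(=O)NC(=O)c1ccc(Nc2nc(NC3(c4ccc(Cl)cc4)CC3)nc(OCC(F)(F)F)n2)cc1`, gives 85% in this assay.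

Compound 3 holds the second highest of the three numbers. Its nearest neighbour is compound 2, with a number 1 percentage points higher from compound 2 to compound 3 (within the scatter), and its furthest is compound 1, with a number 8 percentage points lower from compound 1 to compound 3 (within the scatter); all three compounds therefore sit within the scatter of one another in this assay.

Compound 4, `CC(C)NCCS(=O)(=O)NC(=O)c1ccc(Nc2nc(NC3(c4ccc(Cl)cc4)CC3)nc(OCC(F)(F)F)n2)cc1`, is not yet measured. It differs from compound 3 by (isopropylamino)methyl in place of hydrogen on a saturated chain carbon bound to a sulfonyl sulfur. Among the measured compounds shown here, two measured steps bear on this change, since both move between a hydrogen and a substituted methyl at the same saturated chain carbon bound to a sulfonyl sulfur: a number 8 percentage points lower from compound 1 to compound 3 (within the scatter) and a number 1 percentage points higher from compound 2 to compound 3 (within the scatter). Neither of these steps left the scatter, so the same place has so far tolerated a (((tert-butyl)carbamoyl)amino)methyl and a ((isopropylcarbonyl)amino)methyl without a clear shift in this assay.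

Compound 4 is therefore expected to show a step of no change at the digits printed from compound 3 to compound 4 (within the scatter), that is, no change beyond the scatter. The estimate for compound 4 is 85%, with a range from 70% to 95%.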

Compound 4, percent of the compound remaining: 100%
Estimate against measurement, compound 4: 15 percentage points below; the measured number lies above the stated range.
By their numbers in this assay, from the lowest: compounds 2, 3, 1 and 4 (each within the scatter of the next, the first and the last beyond it).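

Among the compounds shown here, at the saturated chain carbon bound to a sulfonyl sulfur, (isopropylamino)methyl is the one group whose step from the hydrogen of compound 3 lies beyond the scatter in this assay, with a number 15 percentage points higher from compound 3 to compound 4 (beyond the scatter), so this position does not respond alike to every substituent. The amine nitrogen of the chain also proves sensitive to what it carries: isopropyl in place of isopropylcarbonyl gives a number 16 percentage points higher from compound 2 to compound 4 (beyond the scatter), beyond the scatter, whereas isopropyl in place of (tert-butyl)carbamoyl gives a number 7 percentage points higher from compound 1 to compound 4 (within the scatter), within it, leaving compound 1 and compound 4 unseparated by this read-out. Nothing available here accounts for these steps.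

On these data alone, what remains open is whether the shift belongs to the amine nitrogen itself or to the isopropyl on it, a question that an unsubstituted amine or a dimethylamino group on the same chain would address. Also open, as far as these compounds go, is how a longer chain carrying the same isopropylamino group, or a carboxylic acid in place of the amine, would read in this assay.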